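The source may report more compounds than this note shows. Statements on the series, on what has been measured and on what is new or still open speak of the compounds shown alone.

Measured compounds:
compound 1 `CN1CCC[C@H]1COc1cncc(O)c1` gives 3.7 nM in an assay on cell membranes for displacement of a labelled ligand from Neuronal acetylcholine receptor; alpha4/beta2 (Rattus norvegicus), read by scintillation counting; a lower number here means a stronger inhibitor, a higher number a weaker inhibitor;
compound 2 `COc1ccc(O)cc1OC[C@@H]1CCCN1` gives 1080 nM in this assay.

Compound 2 has the higher of the two numbers in this assay; its nearest neighbour, compound 1, sits far lower, well beyond the scatter. Compound 3 `Oc1cccc(OC[C@@H]2CCCN2)c1` is reached from compound 2 by hydrogen in place of methoxy on an aromatic carbon. For the measured compounds named here, no measured pair shows this change, so the direction rests on expectation alone: compound 3 is expected to give a lower number, a step of moderate size in a 5.4-fold lower number from compound 2 to compound 3 (0.73 log units; beyond the scatter). Compound 3 is estimated at 200 nM, within 40 nM to 1000 nM.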

Compound 3, inhibition constant: 407 nM
Compound 3: the middle estimate sits 2.0-fold (0.31 log units) below what was measured; the range from low to high includes it.
By their numbers in this assay, from the lowest: compound 1; then compound 3; then compound 2.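

Placing hydrogen in place of methoxy on the aromatic carbon para to a hydroxy group gives a 2.7-fold lower number from compound 2 to compound 3 (0.42 log units; beyond the scatter) in this assay and is the first change here confined to one place. At this position, the methoxy of compound 2 is therefore not needed for the number seen, and its loss brings a modest gain. On these data alone, whether a fluoro group or a longer chain such as ethoxy on this carbon would move the number the same way stays open. Nothing measured here accounts for the step.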